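The compounds below may be only part of what the source reports. "The series", "measured", "known", "first", "only" and "open" are said of these compounds alone.

Compound 1 `CCCC/C=C\CCCCCCCCCc1cc(=O)c2c(O)cc(O)c(C)c2o1` in a functional assay on MCF7 cells (Homo sapiens) for antiproliferative activity, read by MTT assay (on this read-out higher numbers stand for weaker inhibition and lower numbers for stronger inhibition), gives 17500 nM, and compound 2 `CCCCC/C=C\C/C=C\CCCCCCCC1(O)CC(=O)c2c(O)cc(O)cc2O1` gives 17500 nM; the two values lie within the scatter of each other, so no order between them is drawn. Compound 3 `CCCCCCCCCCCCCCCC1(O)CC(=O)c2c(O)cc(OCOC)cc2O1` in this assay reaches only a limit, > 67200 nM, not a number. Compound 3 therefore sits at the limit of > 67200 nM in this assay, at which 1 of the 3 values shown sits, the sole limit among the three values. Compound 4 `CCCCC/C=C\C/C=C\CCCCCCCC1(O)CC(=O)c2c(O)cc(OCOC)cc2O1` differs from compound 3 by deca-1,4-dien-1-yl in place of octyl on a saturated chain carbon, seven bonds along the chain from a saturated ring carbon. Within the data shown here, no measured pair is separated by this change alone, so its size is not fixed by the data. Compound 2 carries the same chain and gives 17500 nM, so for compound 4 a shift toward stronger inhibition in this assay is expected, though possibly not beyond the scatter. Compound 4 is expected at 50000 nM, between 15000 nM and 150000 nM, a step of an at least 1.3-fold lower number from compound 3 to compound 4 (0.12 log units; that floor lies within the scatter).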

Compound 4, half-maximal inhibitory concentration: > 84100 nM
Compound 4: only a limit was reported; the forecaster's own chance of this, stated with the estimate: 50%; middle value at least 1.6-fold (0.22 log units) from the limit.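

In this assay compound 4 gives only a limit, > 84100 nM. With compound 3 also at a limit, the change from octyl to deca-1,4-dien-1-yl cannot be read. Among these compounds, with the chain held the same, methoxymethyl in place of hydrogen on an oxygen on an aromatic ring gives an at least 4.8-fold higher number from compound 2 to compound 4 (0.68 log units; beyond the scatter), the first readable single change.

From the compounds shown here alone, whether the chain change has any effect when that oxygen carries hydrogen remains open. Also open, going by these compounds, is whether a different group on that oxygen, such as acetyl, would give a similar step.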